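Three Inactive Analogues and a Fourth Still Untested

A few compounds are considered here, and "the series" means these few. Any claim that something is new, unique, unknown or untested is made for them only; others in the source may bear on it.

Compound 1 `O=S1(=O)CCC(CNCCCCN(C[C@H]2Cc3ccccc3CN2)[C@H]2CCCc3cccnc32)CC1`: in a functional assay on cells for agonist activity at C-X-C chemokine receptor type 4 (Homo sapiens), read by fluorescence and calcium flux, with a stated time of 90 s (a higher number here means that more compound is needed for the effect, a lower number that less compound is needed), compound 1 gives > 30000 nM, a limit of the assay.
Compound 2 `c1ccc2c(c1)CN[C@@H](CN(CCCCNC1CCCCC1)[C@H]1CCCc3cccnc31)C2`: in this assay compound 2 gives > 30000 nM, a limit of the assay.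
Compound 3 `O=S1(=O)CCC(NCCCCN(C[C@H]2Cc3ccccc3CN2)[C@H]2CCCc3cccnc32)CC1`: in this assay compound 3 gives > 30000 nM, a limit of the assay.

Compound 2 stands at the limit, as do both other measured compounds; the observed point is the limit of > 30000 nM in this assay, at which 3 of the 3 values shown sit. The change to compound 4 `C(=C/CN(C[C@H]1Cc2ccccc2CN1)[C@H]1CCCc2cccnc21)\CNC1CCOCC1` is 3-((oxan-4-yl)amino)prop-1-en-1-yl in place of 3-(cyclohexylamino)propyl on a saturated chain carbon bound to an amine nitrogen. The steps between the measured compounds, a step that the two limits leave unreadable from compound 1 to compound 2, a step that the two limits leave unreadable from compound 1 to compound 3 and a step that the two limits leave unreadable from compound 2 to compound 3, all compare limits and so show no size, in either direction. None of them alters the chain that is changed here, so they give no direct guide. With every measured value at the limit, the expected step that the limit leaves unreadable from compound 2 to compound 4 is no readable change. Compound 4 is estimated at 40000 nM in this assay, with a range from 15000 nM to 150000 nM, and most likely only a limit will again be reported.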

Compound 4, half-maximal effective concentration: > 30000 nM
Compound 4 was reported as a limit; the forecaster's own chance of this, stated with the estimate: 80%; the middle value does not contradict the limit.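

In this assay compound 4 gives > 30000 nM, a limit of the assay. Compound 2 also stands at a limit, so no step can be read from compound 2 to compound 4. The compounds shown leave open which structural change, if any, would bring a value within the readable range of this assay.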